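A Methyl-to-Chloro Swap in a Sulfone Pair

This account rests on a few compounds, and the source may have more. Where it says the series, first, only, none or still open, it means among the compounds named here.

Compound 1 `CCOc1cc(/C=C(\C(=O)c2ccc(Cl)cc2)S(=O)(=O)Cc2ccc(Cl)cc2)ccc1O`: 10000 nM
Compound 2 `Cc1ccc(CS(=O)(=O)/C(=C/c2cc(C)ccc2C)C(=O)c2ccc(Cl)cc2)cc1`: 1000 nM

Both numbers come from a functional assay on DU-145 cells (Homo sapiens) for inhibition, read by trypan blue exclusion, with a stated time of 96 h; a higher number here means a weaker inhibitor of growth, a lower number a stronger inhibitor of growth. Compound 2 has the lower of the two numbers, and the gap up to compound 1 lies beyond the usual scatter. Among the measured compounds shown here, the two measured compounds differ in more than one place, so the data hold no measured step for a single change.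

Compound 3 `Cc1ccc(C)c(/C=C(\C(=O)c2ccc(Cl)cc2)S(=O)(=O)Cc2ccc(Cl)cc2)c1` has yet to be measured in this assay. It departs from compound 2 in one place: chloro in place of methyl on an aromatic carbon. This is chloro in place of methyl on an aromatic carbon, para to a large group, and the same difference reads 4-methylbenzyl to 4-chlorobenzyl. For the measured compounds named here, with only this swap of one heavy atom for another, no step beyond the scatter is expected in either direction, and the expectation stays anchored on compound 2 at 1000 nM. The estimated change is a 1.3-fold lower number from compound 2 to compound 3 (0.10 log units; within the scatter). For compound 3 the expected value is 800 nM, with an estimated range of 250 nM to 2500 nM.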

Compound 3, concentration for 50% growth inhibition: 10000 nM
Compound 3: the middle estimate sits 13-fold (1.10 log units) below what was measured; the measured number lies above the stated range.
By their numbers in this assay, from the lowest: compound 2; then compounds 1 and 3 (each within the scatter of the next).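

In this assay, among the compounds shown here, the swap of 4-methylbenzyl to 4-chlorobenzyl is the first single change that can be read, and it gives a 10-fold higher number from compound 2 to compound 3 (1.00 log units; beyond the scatter) and so shows that exchanging one heavy atom on this aromatic carbon, para to a large group, is not silent, with the chloro compound the weaker inhibitor of growth. With 4-chlorobenzyl in place, 2,5-dimethylphenyl in place of 3-ethoxy-4-hydroxyphenyl gives no change at the digits printed from compound 1 to compound 3 (within the scatter) and so, among these three compounds, the methyl-to-chloro step carries the gap, while the change of the other aromatic group leaves no readable mark in this pair. Nothing measured alongside these numbers speaks to why the swap has this size of effect.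

Going by these compounds, it remains open whether the loss belongs to chloro itself or to any departure from methyl at this place, as a fluoro, a methoxy group or a plain hydrogen there would begin to tell. Also open, on these data alone, is whether 3-ethoxy-4-hydroxyphenyl would behave as 2,5-dimethylphenyl does when paired with 4-methylbenzyl rather than 4-chlorobenzyl.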